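The source may hold more compounds than are shown below. What is called first, only, known or untested is meant among the compounds shown, and "the series" means these compounds.

Compound 1 `COc1ccc(-n2ccc(=O)c(C(=O)Nc3ccc(Oc4ccnc5c4ccn5C)c(F)c3)n2)cc1`: in a functional assay on MCF7 cells (Homo sapiens) for cytotoxicity, read by MTT assay, with a stated time of 72 h (on this read-out higher numbers stand for weaker inhibition and lower numbers for stronger inhibition), compound 1 gives > 60000 nM, which is a limit of the assay, not a number.
Compound 2 `Cn1ccc2c(Oc3ccc(NC(=O)c4nn(-c5ccc(Br)cc5)ccc4=O)cc3F)ccnc21`: in this assay compound 2 gives 33600 nM.

Among the compounds with values here, compound 2 holds the only number in this assay; the other value is a limit. The step to compound 3 `Cn1ccc2c(Oc3ccc(NC(=O)c4nn(-c5ccccc5)ccc4=O)cc3F)ccnc21` is hydrogen in place of bromo on an aromatic carbon. Within the data shown here, the one measured step, an at least 1.7-fold lower number from compound 1 to compound 2 (0.25 log units; that floor lies within the scatter), changes the same aromatic carbon, with compound 1 at the limit of > 60000 nM in this assay, at which 1 of the 2 values shown sits. Among the measured compounds shown here, no measured step removes bromo, so an expected step of a 1.3-fold higher number from compound 2 to compound 3 (0.13 log units; within the scatter) is a loose guess, no direction beyond the scatter firmly held. Compound 3 is estimated at 45000 nM, between 15000 nM and 120000 nM.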

Compound 3, half-maximal inhibitory concentration: > 60000 nM
Compound 3 ended at the assay's limit; the forecaster's own chance of this, stated with the estimate: 35%; at least 1.3-fold (0.12 log units) between middle value and limit.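

Hydrogen in place of bromo gives an at least 1.7-fold higher number from compound 2 to compound 3 (0.25 log units; that floor lies within the scatter), so the change from 4-bromophenyl to phenyl shows no firm loss in this assay. The step between compound 1 and compound 3 cannot be read: both values are limits. Only compound 2 carries a number in this assay, and the other two compounds sit at a limit: the limit of > 60000 nM in this assay, at which 2 of the 3 values shown sit.

As far as these compounds go, whether bromo truly differs from hydrogen or methoxy on this aromatic carbon stays open. Also open, from the compounds shown here alone, is whether an amine or a carboxylic acid at this carbon would move the number beyond the scatter.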